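This account rests on a few compounds, and the source may have more. Where it says the series, first, only, none or still open, it means among the compounds named here.

Of the compounds shown here, three have been tested so far in a functional assay on HT-22 cells (Mus musculus), read by MTT assay, with a stated time of 24 h (on this read-out higher numbers stand for an effect only at larger amounts of compound and lower numbers for an effect already at smaller amounts), and none of them gives an exact number. Compound 1 (`COc1cc(-c2ccc(O)cc2)nc2ccccc12`) is reported as "not active" (no number reported) and so is compound 2 (`CCOc1ccc(/C=C/C(=O)c2ccc3ccccc3c2O)cc1OCC`), whose entry reads "not active" (no number reported) without any figure attached. Compound 3 (`COc1cc(-c2ccc(O)cc2O)nc2ccccc12`) comes closest to a measurement, and its result of > 500 nM is a limit of the assay and not a number. Within the data shown here, compound 3 therefore has no exact position on the scale, and there is no measured step between related compounds to use as a guide.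

The next compound, compound 4 (`CC(C)Oc1cc(-c2ccc(O)cc2O)nc2ccccc12`), keeps the core of compound 3 and changes one small group: isopropyl in place of methyl on an oxygen on an aromatic ring. In plain terms, methoxy becomes isopropoxy, with isopropyl in place of methyl on an oxygen on an aromatic ring. Among the measured compounds shown here, with no earlier step to compare, the direction cannot be predicted with confidence, so a modest result is the cautious expectation. The only anchor for that expectation is compound 3, with its limit of > 500 nM as the sole reference point. The expected change, a step that the limit leaves unreadable from compound 3 to compound 4, is no larger than the usual scatter of this kind of measurement. For compound 4 the estimated value is 600 nM, with an expected range from 150 nM to 2500 nM.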

Compound 4, half-maximal effective concentration: 210 nM
Beside the measured number, compound 4's estimate is 2.9-fold (0.46 log units) above it, and the stated range covers the measured number.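

In this assay, the swap of methyl for isopropyl on an oxygen on an aromatic ring gives an at least 2.3-fold lower number from compound 3 to compound 4 (0.37 log units; beyond the scatter), so this position accepts the larger group and the effect then appears at smaller amounts of compound. Compound 3 stands at > 500 nM, which is a limit of the assay and not a number. The change from methoxy to isopropoxy can therefore be read for direction and for a minimum size only, because the sole reference point is that limit: the limit of > 500 nM in this assay, at which 1 of the 4 values shown sits.

Going by these compounds, with only methoxy and isopropoxy to compare at this position, it remains open whether the number keeps falling as the group on the oxygen grows, or whether the branching of isopropyl matters; ethoxy, a longer chain such as butoxy, or a chain ending in an amine would help to separate these possibilities. On these data alone, it is also open whether the same swap would have a similar effect on a different core, such as that of compound 2.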